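Swapping Methyl for Fluoro: Expected Cytotoxicity of Compound 4

A few compounds are considered here, and "the series" means these few. Any claim that something is new, unique, unknown or untested is made for them only; others in the source may bear on it.

Of the compounds shown here, three have been measured in a functional assay on K562 cells (Homo sapiens) for cytotoxicity; a lower number here means that less compound is tolerated, a higher number that more compound is tolerated. Compound 1 `Cc1ccc(C(CCn2ccnc2)Oc2ccc(Cl)cc2Cl)cc1` gives 31400 nM, the lowest of the three numbers. Compound 2 `O=[N+]([O-])c1ccc(OC(CCn2ccnc2)c2ccccc2)cc1` gives 102000 nM, and compound 3 `Fc1ccc(OC(CCn2ccnc2)c2ccccc2)c(F)c1` gives 298000 nM, so both gaps from compound 1 lie beyond the usual scatter of repeated measurements. Compound 4 `Fc1ccc(C(CCn2ccnc2)Oc2ccc(Cl)cc2Cl)cc1` differs from compound 1 in one place: fluoro in place of methyl on an aromatic carbon. Within the data shown here, no measured pair shows this exact change, so nothing among the three measured compounds tells its size directly. Such a swap is expected to shift this assay only slightly, and the step of a 1.1-fold higher number from compound 1 to compound 4 (0.05 log units; within the scatter) is estimated to stay within the scatter. Compound 4 is therefore expected to give about 35000 nM, with a likely range from 12000 nM to 100000 nM.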

Compound 4, half-maximal cytotoxic concentration: 33500 nM
Compound 4: middle estimate off by 1.0-fold (0.02 log units), on the high side; the range from low to high includes it.
By their numbers in this assay, from the lowest: compounds 1 and 4 (each within the scatter of the next); then compound 2; then compound 3.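

In this assay, among these compounds, the 4-methylphenyl to 4-fluorophenyl swap gives a 1.1-fold higher number from compound 1 to compound 4 (0.03 log units; within the scatter) and so provides the first direct reading of this change. At this ring position, on the core of compound 1, methyl and fluoro cannot be told apart. No measurement shown explains why the two groups read alike. On these data alone, whether an amine, a carboxylic acid or a longer chain at this position would also stay close to compound 1 remains open. So does whether the same swap would read alike with other groups elsewhere on the core.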